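Swapping the amide aryl ring on a shared chloro-biaryl core

The source may hold more compounds than are shown below. What is called first, only, known or untested is meant among the compounds shown, and "the series" means these compounds.

Compound 1 `O=C(Nc1ccc(Cl)c(-c2nnc3c(Cl)cccn23)c1)c1c(F)cccc1Cl` — 57600 nM
Compound 2 `CS(=O)(=O)c1cccc(C(=O)Nc2ccc(Cl)c(-c3nnc4c(Cl)cccn34)c2)c1` — > 100000 nM
Compound 3 `O=C(Nc1ccc(Cl)c(-c2nnc3c(Cl)cccn23)c1)c1ccccn1` — > 100000 nM

All three compounds were tested in a functional assay on MDA-MB-468 cells (Homo sapiens) for antiproliferative activity, read by MTT assay, with a stated time of 72 h; a lower number here means a stronger inhibitor, a higher number a weaker inhibitor. Among the compounds with values here, compound 1 gives 57600 nM, the only numerical value of the set. Compound 2 sits at an assay limit rather than a number, > 100000 nM. Compound 3 likewise sits at an assay limit, > 100000 nM, so its standing can only be given as a floor, shared with compound 2 at the limit of > 100000 nM in this assay, at which 2 of the 3 values shown sit.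

The step from compound 1 to compound 3 reads an at least 1.7-fold higher number from compound 1 to compound 3 (0.23 log units; that floor lies within the scatter). The step from compound 2 to compound 3 reads a step that the two limits leave unreadable from compound 2 to compound 3. Compound 4 `O=C(Nc1ccc(Cl)c(-c2nnc3c(Cl)cccn23)c1)c1cccnc1Cl` is not yet measured; the change from compound 3 is 2-chloropyridin-3-yl in place of pyridin-2-yl on a carbonyl carbon.

Within the data shown here, no measured step covers this change directly. Since compound 3 rests at a limit, the step to compound 4 is expected to be small or unreadable, and compound 4 is estimated at 80000 nM, within 30000 nM to 200000 nM. The expected step is an at least 1.2-fold lower number from compound 3 to compound 4 (0.09 log units; that floor lies within the scatter).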

Compound 4, half-maximal inhibitory concentration: > 100000 nM
Compound 4: no number, only a limit; the forecaster's own chance of this, stated with the estimate: 50%; middle value at least 1.2-fold (0.09 log units) from the limit.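

In this assay compound 4 gives > 100000 nM, a limit of the assay and not a number, so a second pyridine ring on the carbonyl carbon, now 2-chloropyridin-3-yl, also stays at the limit: the limit of > 100000 nM in this assay, at which 3 of the 4 values shown sit. The steps joining compound 4 to compound 2 and compound 3 link two limits and cannot be read. Within the data shown here, the one readable step is an at least 1.7-fold higher number from compound 1 to compound 4 (0.23 log units; that floor lies within the scatter), so the series gives no firm order, and compound 1, with its 2-chloro-6-fluorophenyl group, goes against the run of limits as the only compound with a number.

On these data alone, how far the compounds at the limit differ from one another stays open. So does whether an amine or a carboxylic acid on the amide ring would give a number in this assay.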